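Swapping fluoro for trifluoromethyl on a cytotoxicity-limited scaffold

The source may report more compounds than this note shows. Statements on the series, on what has been measured and on what is new or still open speak of the compounds shown alone.

Of the compounds shown here, two from this series have been tested in an ADME assay on HepG2 cells (Homo sapiens) for cytotoxicity, read by resazurin assay, with a stated time of 24 h (a lower number here means a stronger inhibitor, a higher number a weaker inhibitor), and both sit at the edge of what the test can report. Compound 1, `COc1ccc2c(=O)c(-c3ccc(Oc4ccc(OC(F)(F)F)cc4)cc3)c(C)[nH]c2c1`, carries a trifluoromethoxy group on its outer ring. In this assay compound 1 gives > 10000 nM, a limit of the assay rather than a number. Compound 2, `COc1cc2[nH]c(C)c(-c3ccc(Oc4ccc(F)cc4)cc3)c(=O)c2cc1Cl`, carries a fluoro group on the corresponding ring together with a chloro on the core. In this assay compound 2 gives > 10000 nM, which is again a limit and not a number. Compound 2 therefore stands where compound 1 stands, at the limit of > 10000 nM in this assay, at which 2 of the 2 values shown sit, and no difference between the two can be read from these results.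

Compound 3, `COc1cc2[nH]c(C)c(-c3ccc(Oc4ccc(C(F)(F)F)cc4)cc3)c(=O)c2cc1Cl`, is yet to be measured. It differs from compound 2 by trifluoromethyl in place of fluoro on an aromatic carbon. For the measured compounds named here, with both measured compounds resting at the limit, no step has been quantified, so the expectation for compound 3 rests on that shared limit alone. The step from compound 2 to compound 3 is expected to be a step that the limit leaves unreadable from compound 2 to compound 3, that is, no change beyond the scatter. Compound 3 is expected to give about 15000 nM, within a range from 5000 nM to 50000 nM, most likely reported only as a limit.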

Compound 3, half-maximal inhibitory concentration: > 10000 nM
Compound 3: a limit, no number; the forecaster's own chance of this, stated with the estimate: 75%; the middle value does not contradict the limit.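

In this assay compound 3 gives > 10000 nM as a limit of the assay and not a number. The change from compound 2 to compound 3 therefore cannot be read as a step, and all three compounds stand at the same place: the limit of > 10000 nM in this assay, at which 3 of the 3 values shown sit. Still open is the concentration at which any of these compounds would reach half-maximal inhibition, and so whether trifluoromethyl in place of fluoro makes any difference to cytotoxicity.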